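This account rests on a few compounds, and the source may have more. Where it says the series, first, only, none or still open, it means among the compounds named here.

Working notes on the series. Compound 1 `CC1=C(C(=O)Nc2ccccc2Cl)C(c2cccs2)NC(=O)N1` and compound 2 `CC1=C(C(=O)Nc2cccc(Cl)c2)C(c2cccs2)NC(=O)N1` share one core and differ only in which chlorophenyl sits on the amide-type nitrogen. In an ADME assay on Vero cells (Chlorocebus sabaeus) for cytotoxicity, read by XTT assay, with a stated time of 72 h (on this read-out lower numbers stand for higher toxicity in this test and higher numbers for lower toxicity in this test), compound 1 reports only a limit of the test, > 100000 nM. In this assay compound 2 likewise reports only a limit, > 100000 nM. Compound 2 therefore stands at the boundary of the test with no number behind it. The step that the two limits leave unreadable from compound 1 to compound 2 has no readable size, as both entries stop at the limit of > 100000 nM in this assay, at which 2 of the 2 values shown sit. Compound 3 `CC1=C(C(=O)Nc2ccc(Cl)cc2)C(c2cccs2)NC(=O)N1` differs from compound 2 by 4-chlorophenyl in place of 3-chlorophenyl on an amide-type nitrogen. For the measured compounds named here, the only measured step bearing on such a repositioning of the chlorine, a step that the two limits leave unreadable from compound 1 to compound 2, gives no size, so no step beyond the scatter is expected in this assay. Compound 3 is accordingly estimated at 150000 nM, with a range of 50000 nM to 500000 nM. The expected step that the limit leaves unreadable from compound 2 to compound 3 is thus estimated as none beyond the scatter, most likely again reported only as a limit.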

Compound 3, half-maximal cytotoxic concentration: > 100000 nM
Compound 3 was reported as a limit (the forecaster's own chance of this, stated with the estimate: 85%); the middle value lies beyond the limit too.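

In this assay compound 3 also reports only a limit, so no step among compound 1, compound 2 and compound 3 can be read: the limit of > 100000 nM in this assay, at which 3 of the 3 values shown sit.

Going by these compounds, whether the 2-chlorophenyl, 3-chlorophenyl and 4-chlorophenyl groups differ at all on this read-out remains open, as none of the three compounds carries a number.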